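The source may report more compounds than this note shows. Statements on the series, on what has been measured and on what is new or still open speak of the compounds shown alone.

For the measured compounds named here, compound 1 `CC(=O)NCCN(C)c1cccc(OCCCCCCNC(=O)Oc2cccc(-c3ccccc3)c2)c1` in a functional assay on cells for agonist activity at melatonin receptor type 1A (Homo sapiens), read by GTPgammaS binding, with a stated time of 30 min (a lower number here means a smaller maximal response, a higher number a larger maximal response), gives 0.7, the lower of the two numbers measured so far; compound 2 `CC(=O)NCCN(C)c1cccc(OCCCCCCNC(=O)Oc2cccc(-c3cccc(O)c3)c2)c1` gives 0.89. Going by the values given here, the one measured step, a number 0.19 higher from compound 1 to compound 2 (beyond the scatter), concerns a different part of the structure and does not bear on the change below. Compound 3 `CCC(=O)NCCN(C)c1cccc(OCCCCCCNC(=O)Oc2cccc(-c3ccccc3)c2)c1` differs from compound 1 by methyl in place of hydrogen on a saturated chain carbon bound to a carbonyl carbon. Among the compounds with values here, no measured step shows what this change does to the maximal response. Compound 3 is therefore expected to show a step of no change at the digits printed from compound 1 to compound 3 (within the scatter), nothing beyond the scatter. Compound 3 is estimated at 0.7, with a range from 0.55 to 0.85.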

Compound 3, intrinsic activity: the largest response reached, as a fraction of the reference agonist's: 0.77
Beside the measured number, compound 3's estimate is 0.070 below it; the range from low to high includes it.
By their numbers in this assay, from the lowest: compounds 1 and 3 (each within the scatter of the next); then compound 2.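

In this assay, going from acetyl to propanoyl gives a number 0.070 higher from compound 1 to compound 3 (within the scatter), so one added methyl on the saturated chain carbon bound to a carbonyl carbon leaves the maximal response indistinguishable from that of the acetamido compound. For the compounds shown here, this is the only reading so far at this position, and it is a single size of change. No evidence on hand bears on why the response holds here.

Open, from the compounds shown here alone, is how far this tolerance extends: a longer chain such as butanoyl, or an amine or a carboxylic acid in place of the methyl, could hold the maximal response or move it beyond the scatter. Also open, going by these compounds, is whether the hydroxy step seen on the acetyl compounds carries over to the propanoyl compound.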